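The compounds below may be only part of what the source reports. "The series", "measured", "known", "first", "only" and "open" are said of these compounds alone.

Within the data shown here, compound 1 `CCN(C)C(=O)/C=C1\CCc2c(F)cc(F)cc21` gives 100% in a functional assay on the whole organism with Mus musculus as the target, at a dose of 100 mg/kg by the intraperitoneal route (a higher number here means more inhibition at the dose given (going by the name of the read-out), a lower number less inhibition), the higher of the two numbers measured so far. Compound 2 `O=C(/C=C1\CCc2cc(Cl)ccc21)NC1CC1` gives 17% in this assay, a gap beyond the scatter; compound 2 differs from compound 1 in more than one place, so the pair shows only its two values. Compound 3 `CNC(=O)/C=C1\CCc2c(F)cc(F)cc21` is not yet measured; it differs from compound 1 by hydrogen in place of ethyl on an amide-type nitrogen. Among the measured compounds shown here, no measured step of this kind exists, so a moderate loss of inhibition is expected, a number 35 percentage points lower from compound 1 to compound 3 (beyond the scatter). Compound 3 is therefore expected to give 65%, within 25% to 100%.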

Compound 3, a percentage reported as inhibition, in the whole organism at one dose (the size of the read-out at that dose, not a potency): 100%
Compound 3: middle estimate off by 35 percentage points, on the low side, and the stated range covers the measured number.
By their numbers in this assay, from the lowest: compound 2; then compounds 1 and 3 (each within the scatter of the next).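

Hydrogen in place of ethyl on an amide-type nitrogen gives no change at the digits printed from compound 1 to compound 3 (within the scatter) in this assay, the first one-place step in the series. The ethyl group is therefore not needed at this nitrogen for the read-out at this dose, and the methylcarbamoyl group serves as well as the ethyl(methyl)carbamoyl group. Nothing measured bears on why the read-out holds.

Going by these compounds, whether a longer chain such as butyl, or a chain carrying an amine or a carboxylic acid, is accepted on this nitrogen remains open. On these data alone, the read-out gives the size of the inhibition at one dose and not a potency, so any difference between compound 1 and compound 3 at lower doses also remains open.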